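A Dichlorophenyl Swap in a Growth Inhibition Series

The source may report more compounds than this note shows. Statements on the series, on what has been measured and on what is new or still open speak of the compounds shown alone.

In a functional assay on UACC-257 cells (Homo sapiens) for inhibition, read by sulforhodamine B assay, with a stated time of 48 h (on this read-out lower numbers stand for stronger inhibition of growth and higher numbers for weaker inhibition of growth), compound 3 (`COc1cccc(OC)c1/C=N/NC(=O)Cc1csc2nc(-c3ccc(Br)cc3)cn12`) gives 97700 nM, the highest of the three numbers. Compound 1 (`O=C(Cc1csc2nc(-c3ccc(Br)cc3)cn12)N/N=C/c1ccccc1`) gives 31600 nM, and compound 2 (`O=C(Cc1csc2nc(-c3ccc(Br)cc3)cn12)N/N=C/c1ccc(O)cc1`) gives 7760 nM. Compound 4 (`O=C(Cc1csc2nc(-c3ccc(Br)cc3)cn12)N/N=C/c1ccc(Cl)cc1Cl`) awaits measurement and carries 2,4-dichlorophenyl in place of 2,6-dimethoxyphenyl on a carbon with a double bond to nitrogen. Among the compounds with values here, two measured steps bear on this change: the modest 3.1-fold higher number from compound 1 to compound 3 (0.49 log units; beyond the scatter) and the large 13-fold higher number from compound 2 to compound 3 (1.10 log units; beyond the scatter). Within the data shown here, both end at the 2,6-dimethoxyphenyl group, but no measured compound carries chlorine, so the guidance is only indirect. A modest fall toward compound 1 is expected, an estimated 3.5-fold lower number from compound 3 to compound 4 (0.54 log units; beyond the scatter). The estimate for compound 4 is 28000 nM, with an expected range of 9000 nM to 85000 nM.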

Compound 4, concentration for total growth inhibition: > 100000 nM
Compound 4: only a limit was reported; the forecaster's own chance of this, stated with the estimate: 10%; at least 3.5-fold (0.55 log units) between middle value and limit.
By their numbers in this assay, from the lowest: compound 2; then compound 1; then compound 3. At a limit, above all of these: compound 4.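

Compound 4 gives only a limit, not a number, and it stands alone there: the limit of > 100000 nM in this assay, at which 1 of the 4 values shown sits.

Chlorine on this carbon's aromatic ring, which no earlier compound carried, brings no gain: in place of phenyl the 2,4-dichlorophenyl group gives an at least 3.1-fold higher number from compound 1 to compound 4 (0.50 log units; beyond the scatter) and in place of 4-hydroxyphenyl it gives an at least 12-fold higher number from compound 2 to compound 4 (1.11 log units; beyond the scatter) here. The data give an at least 1.0-fold higher number from compound 3 to compound 4 (0.01 log units; that floor lies within the scatter) for 2,4-dichlorophenyl in place of 2,6-dimethoxyphenyl, and such a floor does not settle how compound 3 and compound 4 compare.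

The compounds shown leave open how far compound 4 lies past its limit. They also leave open how an amine or a carboxylic acid in place of the chlorines would read.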